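The compounds below may be only part of what the source reports. "The series", "measured", "known", "first", "only" and "open" are said of these compounds alone.

Measured compounds in an assay on HEK293 cells for antagonist activity at transient receptor potential cation channel subfamily V member 3 (Homo sapiens), read by FLIPR and calcium flux; a lower number here means a stronger inhibitor, a higher number a weaker inhibitor:

- compound 1, `O[C@H](c1ccccn1)[C@]1(c2cc(C(F)(F)F)ccn2)C[C@H](O)C1`: 270 nM
- compound 2, `C[C@]1(c2ccc(OC(F)(F)F)cc2)C[C@@](O)(c2ccccn2)CO1`: 2460 nM
- compound 3, `C[C@]1(O)C[C@@](c2cc(C(F)(F)F)ccn2)([C@H](O)c2ccccn2)C1`: 730 nM

Compound 3 stands second highest of the three numbers. Its nearest neighbour is compound 1, whose number is lower by a margin beyond the scatter; the furthest is compound 2, whose number is higher, again beyond the scatter. Compound 3 shares with compound 1 the hydroxy(pyridin-2-yl)methyl group and the trifluoromethyl-bearing pyridine on the four-membered ring, and differs from it at the ring carbon carrying the hydroxy, where compound 3 carries a methyl and the hydroxy is set on a carbon of the other configuration.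

The next compound, compound 4, `O[C@H](c1ccccn1)[C@]1(c2cc(C(F)(F)F)ccn2)C[C@@H](O)C1`, is not yet measured. It differs from compound 3 in one place: hydrogen in place of methyl on a saturated ring carbon. Within the data shown here, no step between two measured compounds covers exactly this change, so the expected size rests on the neighbours alone. Compound 1, which also carries hydrogen at that ring carbon, gives 270 nM, and compound 3 gives 730 nM; the change removes a single carbon and adds no donor or acceptor.

The expectation for compound 4 is a small step toward a lower number, a 1.8-fold lower number from compound 3 to compound 4 (0.26 log units; within the scatter), possibly within the scatter. The estimate for compound 4 in this assay is 400 nM, with a range from 150 nM to 1100 nM.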

Compound 4, antagonist equilibrium constant: 320 nM
Beside the measured number, compound 4's estimate is 1.3-fold (0.10 log units) above it, and the stated range covers the measured number.
By their numbers in this assay, from the lowest: compounds 1 and 4 (each within the scatter of the next); then compound 3; then compound 2.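

In this assay, among these compounds, hydrogen in place of methyl on a saturated ring carbon of the four-membered ring gives a 2.3-fold lower number from compound 3 to compound 4 (0.36 log units; beyond the scatter), the first reading of a single change at this position, and it shows that the methyl in compound 3 is not needed for the activity of this series. The step is modest, but it lies beyond the scatter, so the methyl comes at a measurable cost here, whereas the earlier comparison of compound 3 with compound 1 mixed this change with a change of configuration. With hydrogen at this ring carbon, the drawn configuration does not separate the compounds, as a 1.2-fold higher number from compound 1 to compound 4 (0.07 log units; within the scatter) stays within the scatter, and the pair allows this clean reading of configuration alone: the fact that compounds 1 and 4 differ only in the configuration as drawn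

As far as these compounds go, how a methyl at this ring carbon would read on the configuration of compound 1 stays open, so the methyl step is known for one configuration only. Also open, from the compounds shown here alone, is whether an ethyl group, a fluorine or an amine at this ring carbon would follow the methyl or the hydrogen in this assay.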